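Compound 4: the Mirror Image of Compound 3

The source may report more compounds than this note shows. Statements on the series, on what has been measured and on what is new or still open speak of the compounds shown alone.

In a functional assay on HCT-116 cells (Homo sapiens) for inhibition, read by MTT assay, with a stated time of 72 h (a lower number here means a stronger inhibitor, a higher number a weaker inhibitor), compound 1 `CC1=NN(c2ccccc2)C(=O)[C@@]12C(=O)C=CC[C@@H]2c1ccccc1[N+](=O)[O-]` reads 66800 nM and compound 2 `CC1=NN(c2ccccc2)C(=O)[C@@]12C(=O)C=CC[C@@H]2c1ccc(C)cc1` reads 5220 nM in the same test. Having 4-methylphenyl in place of 2-nitrophenyl on a saturated ring carbon is a large step (a 13-fold lower number from compound 1 to compound 2 (1.11 log units; beyond the scatter)). Compound 3 `COc1ccccc1[C@@H]1CC=CC(=O)[C@]12C(=O)N(c1ccccc1)N=C2C` reads 2850 nM here, within the scatter of compound 2 and far lower than compound 1. Compound 4 `COc1ccccc1[C@H]1CC=CC(=O)[C@@]12C(=O)N(c1ccccc1)N=C2C` is its mirror image (the two compounds have the same atoms and bonds and differ only in configuration as drawn: 2 of 2 stereo elements differ (all stereocentres are inverted: mirror images); a stereocentre at a saturated ring carbon is drawn S in compound 3 and R in compound 4; a stereocentre at a saturated ring carbon is drawn S in compound 3 and R in compound 4). Within the data shown here, the one measured step changes a group, not configuration, so it offers no guide to this inversion. The expectation therefore rests on compound 3 at 2850 nM alone. No direction can be favoured, so the estimated change is small (a 1.2-fold higher number from compound 3 to compound 4 (0.09 log units; within the scatter)) and no step beyond the scatter is expected in this assay at this point. Compound 4 is expected at 3500 nM (estimated range 1200 nM to 12000 nM).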

Compound 4, half-maximal inhibitory concentration: 13900 nM
Compound 4: the middle estimate sits 4.0-fold (0.60 log units) below what was measured; measured number outside the range, above it.
By their numbers in this assay, from the lowest: compounds 3 and 2 (each within the scatter of the next); then compound 4; then compound 1.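

In this assay, inverting both stereocentres gives a 4.9-fold higher number from compound 3 to compound 4 (0.69 log units; beyond the scatter), so configuration matters at this point, and the step can be assigned to it alone because of one fact: the fact that compounds 3 and 4 differ only in the configuration as drawn. With the configuration of compound 4 held, the group still counts: 2-methoxyphenyl in place of 4-methylphenyl gives a 2.7-fold higher number from compound 2 to compound 4 (0.43 log units; beyond the scatter), and methoxy in place of nitro gives a 4.8-fold lower number from compound 1 to compound 4 (0.68 log units; beyond the scatter). Still open, going by these compounds, is whether inverting compound 1 or compound 2 would shift their numbers in the same way, and how an amine or a carboxylic acid in place of the methoxy would read.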